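A few compounds are considered here, and "the series" means these few. Any claim that something is new, unique, unknown or untested is made for them only; others in the source may bear on it.

Among the measured compounds shown here, compound 2 `C[Si](C)(C)C1=C(Cl)C[C@H](C2CCCCC2)O[C@@H]1C1CCCCC1` gives 23000 nM in a functional assay on SW1573 cells (Homo sapiens) for antiproliferative activity; a lower number here means a stronger inhibitor of growth, a higher number a weaker inhibitor of growth; the only other number in hand, from compound 1 `CC[C@H]1CC(Cl)=C([Si](C)(C)C)[C@@H](C2CCCCC2)O1` at 22000 nM, lies within the scatter of it, so compound 2 stands level with compound 1 rather than apart from it. For the measured compounds named here, the single measured step, a 1.0-fold higher number from compound 1 to compound 2 (0.02 log units; within the scatter), is the replacement of ethyl by cyclohexyl on a saturated ring carbon of the shared core, and it stayed within the scatter. Compound 3 `C[Si](C)(C)C1=C(Cl)C[C@H](Cc2ccccc2)O[C@@H]1C1CCCCC1` carries the change (benzyl in place of cyclohexyl on a saturated ring carbon). Going by the values given here, this step bears the closest resemblance to that one measured step, which was flat, so a step beyond the scatter is not expected in either direction in this assay; the reservation is that only one step at this carbon is known. Compound 3 is therefore expected to give 23000 nM in this assay, with a range of 8000 nM to 65000 nM, an expected step of no change at the digits printed from compound 2 to compound 3 (within the scatter) that sits within the scatter.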

Compound 3, concentration for 50% growth inhibition: 30000 nM
The estimate for compound 3 lay 1.3-fold (0.12 log units) below the measured number, and the stated range covers the measured number.
By their numbers in this assay, from the lowest: compounds 1, 2 and 3 (each within the scatter of the next).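

In this assay, a 1.3-fold higher number from compound 2 to compound 3 (0.12 log units; within the scatter) shows that at this saturated ring carbon next to the ring oxygen, an aromatic ring in benzyl is read level with the non-aromatic ring in cyclohexyl. The second reading, a 1.4-fold higher number from compound 1 to compound 3 (0.13 log units; within the scatter), extends this to phenyl in place of methyl on the saturated chain carbon, so ethyl, cyclohexyl and benzyl at this carbon have not been separated in this series. Nothing at hand bears on why these changes leave the number flat.

Still open, on these data alone, is whether any group at this carbon moves the number beyond the scatter, for example an amine or a carboxylic acid on the chain or on the phenyl ring. Also open, as far as these compounds go, is whether a smaller group, such as methyl or hydrogen, stays level with these three.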